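A few compounds are considered here, and "the series" means these few. Any claim that something is new, unique, unknown or untested is made for them only; others in the source may bear on it.

Compound 1 `CCOc1ccc(C(=O)/C=C/c2c(/C=C/c3ccc(OC)cc3)cc(OC)cc2OC)cc1` is one of three compounds that share a core carrying a methoxyphenyl side chain and an unsaturated ketone. In a functional assay on HepG2 cells (Homo sapiens) for antiproliferative activity, read by MTT assay, with a stated time of 48 h (on this read-out lower numbers stand for stronger inhibition and higher numbers for weaker inhibition), compound 1 gives 8 ug/mL, the second highest of the three numbers. Compound 2 `CCCC(C)Oc1ccc(C(=O)/C=C/c2c(/C=C/c3ccc(OC)cc3)cc(OC)cc2OC)cc1` gives 11.1 ug/mL, and the step of a 1.4-fold higher number from compound 1 to compound 2 (0.14 log units; within the scatter) shows that lengthening the alkoxy group on the carbonyl-bearing ring changes little. Compound 3 `COc1ccc(/C=C/c2cc(OC)cc(OC)c2/C=C/C(=O)c2ccc(C)c(C)c2)cc1` gives 0.2 ug/mL; the step of a 40-fold lower number from compound 1 to compound 3 (1.60 log units; beyond the scatter) is a large drop when the alkoxyphenyl is exchanged for a dimethylphenyl, a change of a different kind.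

Compound 4 `COc1ccc(/C=C/c2cc(OC)cc(OC)c2/C=C/C(=O)c2ccc(OC)cc2)cc1` differs from compound 1 by hydrogen in place of methyl on a saturated chain carbon bound to an oxygen on an aromatic ring. This is the reverse direction of the kind of alkoxy change seen in the step from compound 1 to compound 2, which stayed within the scatter, and it does not touch what changed between compound 1 and compound 3. The expected step is therefore small, a 1.3-fold lower number from compound 1 to compound 4 (0.12 log units; within the scatter). Compound 4 is estimated at 6 ug/mL, with a range from 2.5 ug/mL to 15 ug/mL.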

Compound 4, half-maximal inhibitory concentration: 4.9 ug/mL
For compound 4 the middle estimate is 1.2-fold (0.09 log units) above the measured one; low and high end bracket the measured number.
By their numbers in this assay, from the lowest: compound 3; then compounds 4, 1 and 2 (each within the scatter of the next, the first and the last beyond it).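

In this assay the ethyl of the 4-ethoxyphenyl can be cut back to methyl, and the step of a 1.6-fold lower number from compound 1 to compound 4 (0.21 log units; within the scatter) shows that this shorter chain leaves the number unchanged within the usual scatter. Chain size registers only across the widest change shown, from 1-methylbutyl to methyl, where the step of a 2.3-fold lower number from compound 2 to compound 4 (0.36 log units; beyond the scatter) is modest. Even with the shortest alkoxy group shown, the 3,4-dimethylphenyl remains apart, as the large step of a 25-fold higher number from compound 3 to compound 4 (1.39 log units; beyond the scatter) makes clear, so shortening this chain does not close the gap to compound 3.

Nothing given here accounts for these differences. On these data alone, it remains open whether a hydroxy group or an amine in place of the alkoxy group on this phenyl ring would give a number closer to compound 3 or to compound 4.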